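Substituting the ring amine nitrogen of compound 2

The source may report more compounds than this note shows. Statements on the series, on what has been measured and on what is new or still open speak of the compounds shown alone.

In an ADME assay on NIH3T3 cells (Mus musculus) for cytotoxicity (a higher number here means that more compound is tolerated, a lower number that less compound is tolerated), compound 2 `Fc1cccc(COc2ccc(Nc3ncnc4cc(C#CCN5CCNCC5)sc34)cc2Cl)c1` reads > 50 uM, which is a limit of the assay and not a number. Compound 1 `CN1CCN(CC#Cc2cc3ncnc(Nc4ccc(OCc5cccc(F)c5)c(Cl)c4)c3s2)CC1` gives 4.8 uM in this assay. Compound 3 `CC(C)(C)OC(=O)N1CCN(CC#Cc2cc3ncnc(Nc4ccc(OCc5cccc(F)c5)c(Cl)c4)c3s2)CC1` is changed on the same nitrogen that separates these two: tert-butoxycarbonyl in place of hydrogen on an amine nitrogen in a ring.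

Within the data shown here, only one measured step bears on this change, an at least 10-fold higher number from compound 1 to compound 2 (1.01 log units; beyond the scatter), with hydrogen in place of methyl. It is large and beyond the scatter. Read in reverse, it suggests that a group on this nitrogen lowers the number, although methyl is far smaller than tert-butoxycarbonyl and a single step fixes no size. An estimated step of an at least 4.1-fold lower number from compound 2 to compound 3 (0.61 log units; beyond the scatter) is therefore expected, towards a lower number, and of a size similar to the measured one. For compound 3 the expected value is 12 uM, with an estimated range of 3 uM to 50 uM.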

Compound 3, half-maximal toxic concentration: 47 uM
The estimate for compound 3 lay 3.9-fold (0.59 log units) below the measured number; low and high end bracket the measured number.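

Tert-butoxycarbonyl in place of methyl gives a 9.8-fold higher number from compound 1 to compound 3 (0.99 log units; beyond the scatter). In this assay, a group on this ring nitrogen therefore does not by itself bring the low number: among the three compounds, only the methyl compound, compound 1, reads low. Compound 2 reads > 50 uM, which is a limit of the assay and not a number. Its step with the tert-butoxycarbonyl compound, an at least 1.0-fold lower number from compound 2 to compound 3 (0.02 log units; that floor lies within the scatter), therefore gives only a floor and leaves any true gap unsized: the limit of > 50 uM in this assay, at which 1 of the 3 values shown sits.

From the compounds shown here alone, it remains open whether the low number is specific to methyl or extends to other small alkyl groups such as ethyl or isopropyl. Going by these compounds, it is also open whether an acetyl group, a carbonyl-linked group far smaller than tert-butoxycarbonyl, would read like compound 3 or like compound 1.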